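Nitrofuran for pyridine at the chain carbon of compound 3

The compounds below may be only part of what the source reports. "The series", "measured", "known", "first", "only" and "open" are said of these compounds alone.

Compound 1 `O=C(c1ccc(F)cc1)c1cccc(/C=c2\[nH]c(=O)/c(=C/c3nc[nH]c3C3CC3)[nH]c2=O)c1`: 2.8 nM
Compound 2 `Cc1[nH]cnc1/C=c1\[nH]c(=O)/c(=C/c2cccc(C(=O)c3ccc(F)cc3)c2)[nH]c1=O`: 15.9 nM
Compound 3 `O=c1[nH]/c(=C\c2ccccn2)c(=O)[nH]/c1=C\c1cccc(Oc2ccc(F)cc2)c1`: 49.1 nM

All three were tested in a functional assay on NCI-H460 cells (Homo sapiens) for cytotoxicity, read by MTT assay, with a stated time of 72 h; a higher number here means a weaker inhibitor, a lower number a stronger inhibitor. Compound 3 gives the highest number of the three; compound 1 gives a lower number and compound 2 sits between them. For the measured compounds named here, the one single-point step among them, a 5.7-fold higher number from compound 1 to compound 2 (0.75 log units; beyond the scatter), concerns a methyl in place of cyclopropyl on an aromatic carbon, a change at a different place from the one considered here, so it does not bear on it. Compound 4 `O=c1[nH]/c(=C\c2ccc([N+](=O)[O-])o2)c(=O)[nH]/c1=C\c1cccc(Oc2ccc(F)cc2)c1` differs from compound 3 as follows: 5-nitrofuran-2-yl in place of pyridin-2-yl on a double-bonded chain carbon bound to an aromatic carbon. No measured step tests this change, and the direction of its effect cannot be read from the shown compounds. The estimate for compound 4 is therefore centred near compound 3, at 60 nM, with a wide range from 10 nM to 400 nM, amounting to an expected step of a 1.2-fold higher number from compound 3 to compound 4 (0.09 log units; within the scatter).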

Compound 4, half-maximal inhibitory concentration: > 1000 nM
Compound 4 gave a limit, no number (the forecaster's own chance of this, stated with the estimate: 5%); at least 16-fold (1.22 log units) between middle value and limit.
By their numbers in this assay, from the lowest: compound 1; then compound 2; then compound 3. At a limit, above all of these: compound 4.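

In this assay, this position is shown to be sensitive to the ring it carries: 5-nitrofuran-2-yl in place of pyridin-2-yl gives an at least 20-fold higher number from compound 3 to compound 4 (1.30 log units; beyond the scatter), so the step's full size stays unknown. Compound 4 gives a limit, not a number: the limit of > 1000 nM in this assay, at which 1 of the 4 values shown sits. For the compounds shown here, the one earlier step concerned methyl and cyclopropyl at a different place, so this is the first measured change at this chain carbon.

From the compounds shown here alone, whether the loss follows the nitro group or the furan ring remains open. A plain furan-2-yl, or an amine in place of the nitro group, would help separate the two.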